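Chloro to methyl on the benzyl group of compound 3

This account rests on a few compounds, and the source may have more. Where it says the series, first, only, none or still open, it means among the compounds named here.

- compound 1 `CN(C)Cc1ccc2nc(NC(=O)N/N=C/c3cn(Cc4ccc(C(C)(C)C)cc4)c4ccccc34)sc2c1`: 810 nM
- compound 2 `CN(C)Cc1ccc2nc(NC(=O)N/N=C/c3c[nH]c4ccccc34)sc2c1`: 2550 nM
- compound 3 `CN(C)Cc1ccc2nc(NC(=O)N/N=C/c3cn(Cc4ccc(Cl)cc4)c4ccccc34)sc2c1`: 290 nM

All three values come from a functional assay on NCI-H460 cells (Homo sapiens) for cytotoxicity, read by MTT assay, with a stated time of 72 h; a lower number here means a stronger inhibitor, a higher number a weaker inhibitor. Compound 3 holds the lowest number of the series, at 290 nM. Compound 4 `Cc1ccc(Cn2cc(/C=N/NC(=O)Nc3nc4ccc(CN(C)C)cc4s3)c3ccccc32)cc1` differs from it by methyl in place of chloro on an aromatic carbon, para to a large group.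

Going by the values given here, no methyl analogue has been measured. The nearest evidence is a 2.8-fold lower number from compound 1 to compound 3 (0.45 log units; beyond the scatter), with chloro in place of tert-butyl on an aromatic carbon. Two further steps, an 8.8-fold lower number from compound 2 to compound 3 (0.94 log units; beyond the scatter) and a 3.1-fold higher number from compound 1 to compound 2 (0.50 log units; beyond the scatter), separate the unsubstituted compound from the two benzyl compounds. Compound 4 keeps a substituted benzyl group, so a return towards compound 2 is not expected. Its value is instead expected to lie near the range spanned by the two benzyl compounds, closer to the chloro end.

The expected step is small and upward in this assay, estimated as a 1.4-fold higher number from compound 3 to compound 4 (0.16 log units; within the scatter). The estimated value for compound 4 is 420 nM, with an expected range of 190 nM to 900 nM.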

Compound 4, half-maximal inhibitory concentration: 200 nM
For compound 4 the middle estimate is 2.1-fold (0.32 log units) above the measured one; the measured number falls inside the stated range.
By their numbers in this assay, from the lowest: compounds 4 and 3 (each within the scatter of the next); then compound 1; then compound 2.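

In this assay, the exchange of chloro for methyl on the aromatic carbon para to a large group gives a 1.5-fold lower number from compound 3 to compound 4 (0.16 log units; within the scatter), so the data do not separate these two substituents at this position. With methyl in place of tert-butyl, the series shows a 4.1-fold lower number from compound 1 to compound 4 (0.61 log units; beyond the scatter), which places tert-butyl apart from both chloro and methyl here. The 4-methylbenzyl group on the aromatic nitrogen gives a 13-fold lower number from compound 2 to compound 4 (1.11 log units; beyond the scatter), so a second small para substituent also stands clear of the compound with hydrogen on that nitrogen. No available evidence bears on the reason for these differences. Still open, on these data alone, is how an unsubstituted benzyl group compares on the aromatic nitrogen. Also open, as far as these compounds go, is how methoxy, an amine or a carboxylic acid would read on this same aromatic carbon.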